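Removing one chloro from an inactive compound

The source may report more compounds than this note shows. Statements on the series, on what has been measured and on what is new or still open speak of the compounds shown alone.

Measured so far in a functional assay on HCT-15 cells (Homo sapiens) for antiproliferative activity; a lower number here means a stronger inhibitor of growth, a higher number a weaker inhibitor of growth:
- Compound 1 `COc1ccc(-n2cc(-c3ccc(Cl)cc3)[nH]c2=S)cc1Cl` gives > 100000 nM as a limit
- Compound 2 `COc1cc(-n2cc(-c3ccc(Cl)cc3)[nH]c2=O)cc(OC)c1OC` gives > 100000 nM as a limit
- Compound 3 `COc1ccc(-c2cn(-c3ccc(Cl)cc3)c(=S)[nH]2)cc1OC` gives 5010 nM as a number

Compound 2 stands at > 100000 nM as a limit of the assay, not a number. This is the limit of > 100000 nM in this assay, at which 2 of the 3 values shown sit, and compound 1 sits there too. Within the data shown here, compound 3 alone gives a number, but it differs from compound 2 in more than one place, so no measured pair isolates the change ahead.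

Compound 4 `COc1cc(-n2cc(-c3ccccc3)[nH]c2=O)cc(OC)c1OC` carries hydrogen in place of chloro on an aromatic carbon, para to a large group, so 4-chlorophenyl becomes phenyl hydrogen in place of chloro on an aromatic carbon and nothing else changes. No measured step sizes this change in this assay. The expectation rests on compound 2 at > 100000 nM as a limit, so compound 4 is expected to stay weak, quite possibly at the same limit. The expected change is a number no higher from compound 2 to compound 4 (the limit leaves the size open) and none beyond the scatter. Compound 4 is estimated at 100000 nM with a range from 20000 nM to 100000 nM as the expected span.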

Compound 4, concentration for 50% growth inhibition: 79400 nM
The estimate for compound 4 lay 1.3-fold (0.10 log units) above the measured number; the measured number falls inside the stated range.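

In this assay, hydrogen in place of chloro on this aromatic carbon gives an at least 1.2-fold lower number from compound 2 to compound 4 (0.10 log units; that floor lies within the scatter). Compound 2 gives only a limit, so the true size of this step stays unknown: the limit of > 100000 nM in this assay, at which 2 of the 4 values shown sit.

Even so, compound 4 gives 79400 nM, an actual number, which shows that the phenyl compound remains a weak inhibitor of growth without the chloro and offers a measured reference point for later changes at this position.

The compounds shown leave open whether an amine or a carboxylic acid on this carbon would give a clearly different number from that of compound 4. They also leave open whether hydrogen in place of chloro would have any measurable effect in compound 1, which also carries 4-chlorophenyl.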